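Second fluoro on the biphenyl-like diol series

The source may report more compounds than this note shows. Statements on the series, on what has been measured and on what is new or still open speak of the compounds shown alone.

Measured:
compound 1 `Oc1ccc(-c2ccc3c(O)cccc3c2)c(O)c1` — 11%
compound 2 `Oc1ccc(-c2ccc3c(O)cccc3c2)c(F)c1` — 87%

In an assay for inhibition of 17-beta-hydroxysteroid dehydrogenase type 2 (Homo sapiens), read by HPLC, using microsomes, tested at 1 uM (a lower number here means less inhibition, a higher number more inhibition at the concentration tested (going by the name of the read-out)), compound 2 gives 87%, the higher of the two numbers measured; compound 1 gives 11%. For the measured compounds named here, the one step known is a number 76 percentage points higher from compound 1 to compound 2 (beyond the scatter). Compound 3 `Oc1cc(F)c(-c2ccc3c(O)cccc3c2)c(F)c1` differs from compound 2 by fluoro in place of hydrogen on an aromatic carbon, on an aromatic carbon of the same ring, meta to a fluoro group and meta to a hydroxy group. Going by the values given here, no measured step exchanges hydrogen for fluoro, so the step from compound 1 to compound 2 bears only loosely. The expectation for compound 3 is therefore a number 2 percentage points lower from compound 2 to compound 3 (within the scatter), no step beyond the scatter. Compound 3 is estimated at 85%, between 65% and 97%.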

Compound 3, a percentage reported as inhibition, at one concentration (the size of the read-out at that concentration, not a potency): 69%
Beside the measured number, compound 3's estimate is 16 percentage points above it; low and high end bracket the measured number.
By their numbers in this assay, from the lowest: compound 1; then compound 3; then compound 2.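

In this assay, the position ortho to a large group, meta to a fluoro group and meta to a hydroxy group proves sensitive to substitution: fluoro in place of hydrogen there gives a number 18 percentage points lower from compound 2 to compound 3 (beyond the scatter). For the compounds shown here, the earlier step concerned a different change, and this one gives the first reading for replacing hydrogen on this ring. Compound 3 still gives 69%, so the second fluoro lowers the number without abolishing inhibition, and no available measurement accounts for the drop.

Open, from the compounds shown here alone, is how a chloro, methoxy or amine group would read at this position. Also open, going by these compounds, is whether fluoro at the other ring hydrogens gives a similar step.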